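The source may report more compounds than this note shows. Statements on the series, on what has been measured and on what is new or still open speak of the compounds shown alone.

Series notes, read-out on whole animals. Compound 1 `COc1cc(OC)c(OC)cc1/C=C/COC(=O)/C=C/c1ccc(Br)cc1` and compound 2 `COc1cc(OC)c(OC)cc1/C=C/COC(=O)/C=C/c1cc(OC)c(OC)c(OC)c1` share the same core and differ only in the aryl group at the far end of the ester. In a functional assay on the whole organism (strain Kunming) with Mus musculus as the target, with a stated time of 0.5 h, at a dose of 300 mg/kg by the intraperitoneal route (on this read-out higher numbers stand for a weaker effect at the one dose given and lower numbers for a stronger effect), compound 1 gives 25%. In this assay compound 2 gives 25%. Compound 1 thus stands level with compound 2 at the digits shown, within the scatter, so the two aryl variants so far show no separation on this read-out.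

Compound 3 `COc1cc(OC)c(OC)cc1/C=C/COC(=O)/C=C/c1ccccc1Cl` is the next member awaiting a number. It differs from compound 1 as follows: 2-chlorophenyl in place of 4-bromophenyl on a double-bonded chain carbon bound to a double-bonded chain carbon. Within the data shown here, no measured pair in the set follows this change, so there is no step of the same kind to lean on; with compound 1 and compound 2 level, the expectation for the step from compound 1 to compound 3 in this assay is no change beyond the scatter, in either direction, expected as no change at the digits printed from compound 1 to compound 3 (within the scatter). Compound 3 is accordingly estimated at 25%, within a range from 10% to 45%.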

Compound 3, a percentage reported as activity, at one dose (the size of the read-out at that dose, not a potency): 25%
The estimate for compound 3 equals the measured number at the digits printed, and the stated range covers the measured number.
By their numbers in this assay, from the lowest: compounds 1, 2 and 3 (each within the scatter of the next).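

Among these compounds, the step in this assay is the first single-place change read at this position, on a double-bonded chain carbon bound to a double-bonded chain carbon, and it reads no change at the digits printed from compound 1 to compound 3 (within the scatter). Here 2-chlorophenyl in place of 4-bromophenyl changes both the halogen and where it sits on the ring, and the read-out does not separate the two aryl groups at the one dose given. No supporting measurement bears on this result.

The compounds shown leave open whether the two parts of this change would each stay level if taken alone, for instance with 4-chlorophenyl at this place. They also leave open whether a phenyl ring carrying an amine or a carboxylic acid, or a longer chain in place of the ethenyl link, would move the read-out away from compound 1.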